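Methyl on the benzyl group of compound 1

The source may hold more compounds than are shown below. What is called first, only, known or untested is meant among the compounds shown, and "the series" means these compounds.

Of the compounds shown here, two have been read so far in a toxicity assay on NIH3T3 cells (Mus musculus) for cytotoxicity, read by resazurin assay; on this read-out higher numbers stand for an effect only at larger amounts of compound and lower numbers for an effect already at smaller amounts: compound 1 `COC(=O)c1ccc(NCc2cncn2Cc2ccccc2)cc1-c1ccccc1` and compound 2 `Cc1cccc(-c2cccc(NCc3cncn3Cc3ccccc3)c2)c1C`. Compound 1 gives > 1000 nM, which is a limit of the assay and not a number. Compound 2 gives > 1000 nM, again a limit. Within the data shown here, the data so far therefore amount to the limit of > 1000 nM in this assay, at which 2 of the 2 values shown sit, and no measured step is available.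

Compound 3 `COC(=O)c1ccc(NCc2cncn2Cc2ccccc2C)cc1-c1ccccc1` differs from compound 1 by methyl in place of hydrogen on an aromatic carbon, turning benzyl into 2-methylbenzyl. No step beyond the scatter is expected in this assay, and no direction is favoured. The expected change is a step that the limit leaves unreadable from compound 1 to compound 3. Compound 3 is estimated at 2000 nM, with an expected range of 800 nM to 8000 nM, and will most likely be reported only as a limit.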

Compound 3, half-maximal effective concentration: 10000 nM
For compound 3 the middle estimate is 5.0-fold (0.70 log units) below the measured one, outside the stated range (above it).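

Among these compounds, no step from compound 1 to compound 3 can be read in this assay, because the value of compound 1 is only a limit: the limit of > 1000 nM in this assay, at which 2 of the 3 values shown sit. The compounds shown leave open how large the change from benzyl to 2-methylbenzyl is, and in which direction it goes.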